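A few compounds are considered here, and "the series" means these few. Any claim that something is new, unique, unknown or untested is made for them only; others in the source may bear on it.

Measured so far in a functional assay on the whole organism with Mus musculus as the target; on this read-out higher numbers stand for an effect only at larger amounts of compound and lower numbers for an effect already at smaller amounts:
- compound 1 `Clc1ccc(N2N=NCC2c2ccncc2)cc1` — 43.5 mg/kg
- compound 2 `FC(F)(F)c1cccc(N2N=NCC2c2ccncc2)c1` — 51.1 mg/kg
- compound 3 `Clc1ccc(-n2nncc2-c2cccnc2)cc1` — 27 mg/kg

Compound 3 carries the chloro substituent on the phenyl ring para to a large group. Its number in this assay is the one at the bottom of the three values, but the values of compound 1 and of compound 2 both lie within the scatter of it, so the three compounds cannot be told apart on this read-out. For the measured compounds named here, compounds 1 and 2 differ from compound 3 in more than one place, and no single-change step between measured compounds is available.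

Compound 4 `FC(F)(F)c1ccc(-n2nncc2-c2cccnc2)cc1` is not yet measured. It differs from compound 3 by trifluoromethyl in place of chloro on an aromatic carbon. Going by the values given here, with no comparable step on record, the only guide is that compound 1, with chloro, and compound 2, with trifluoromethyl, give numbers within the scatter of each other. No step beyond the scatter is expected in this assay from compound 3 to compound 4. Compound 4 is therefore estimated at 30 mg/kg, with a range from 15 mg/kg to 60 mg/kg, which corresponds to an expected step of a 1.1-fold higher number from compound 3 to compound 4 (0.05 log units; within the scatter).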

Compound 4, dose for half-maximal effect: 90.5 mg/kg
Beside the measured number, compound 4's estimate is 3.0-fold (0.48 log units) below it; the whole stated range lies below it.
By their numbers in this assay, from the lowest: compounds 3, 1, 2 and 4 (each within the scatter of the next, the first and the last beyond it).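

In this assay, for the compounds shown here, the exchange of chloro for trifluoromethyl on an aromatic carbon, para to a large group, gives a 3.4-fold higher number from compound 3 to compound 4 (0.53 log units; beyond the scatter) as the first single-change step. This position of compound 3 therefore does not tolerate every substituent equally on this read-out, which compounds 1, 2 and 3 could not show, as they differ from one another in more than one place. No accompanying measurement bears on the origin of this step.

On these data alone, how a methoxy group, an amine or a carboxylic acid at this position would compare with chloro remains open. Also open, as far as these compounds go, is whether the same exchange at the matching position on the core of compound 1 would give a step of similar size.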